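The compounds below may be only part of what the source reports. "The series", "measured", "known", "first", "only" and "open" are said of these compounds alone.

Of the compounds shown here, two from this series have been measured so far, both in a functional assay on HeLa cells (Homo sapiens) for inhibition, read by sulforhodamine B assay; on this read-out higher numbers stand for weaker inhibition and lower numbers for stronger inhibition. Compound 1, `O=C1C(Nc2ccc(Br)cc2)=CC(=O)c2c1nc1n2[C@H]2OC[C@@H](O)[C@H]2OC1`, gives 5220 nM in this assay. Compound 2, `CCc1ccc(NC2=CC(=O)c3nc4n(c3C2=O)[C@H]2OC[C@@H](O)[C@H]2OC4)cc1`, gives 3990 nM in this assay. Within the data shown here, only these two numbers exist, and they sit within the usual scatter of repeated measurements of each other, so compound 1 cannot be set apart from compound 2 on this evidence; no step between measured compounds that differ in one place has been recorded.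

The next compound, compound 3, `COc1cccc(NC2=CC(=O)c3c(nc4n3[C@H]3OC[C@@H](O)[C@H]3OC4)C2=O)c1`, differs from compound 1 in one place: 3-methoxyphenyl in place of 4-bromophenyl on an amine nitrogen. Among the measured compounds shown here, nothing measured so far shows how an exchange of this kind on the amine nitrogen moves the numbers in this assay, since the two measured compounds differ from each other in a different way.

For the measured compounds named here, with no measured step to build on, the expectation for compound 3 is conservative: the step of a 1.0-fold lower number from compound 1 to compound 3 (0.02 log units; within the scatter) is estimated to be small, without a clear direction, and likely within the scatter. Compound 3 is therefore expected to give about 5000 nM in this assay, with a plausible range from 1800 nM to 14000 nM.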

Compound 3, half-maximal inhibitory concentration: > 8000 nM
Compound 3: only a limit was reported; the forecaster's own chance of this, stated with the estimate: 5%; at least 1.6-fold (0.20 log units) between middle value and limit.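

Compound 3 is reported only as a limit, not as a number: the limit of > 8000 nM in this assay, at which 1 of the 3 values shown sits. On the amine nitrogen, 3-methoxyphenyl in place of 4-bromophenyl gives an at least 1.5-fold higher number from compound 1 to compound 3 (0.18 log units; that floor lies within the scatter) in this assay. This is the only step shown at this position, and it offers no sign that this exchange brings stronger inhibition, although the floor of the step lies within the scatter, so a real weakening cannot be claimed and the true size of the step remains unknown.

This exchange alters two things at once, the identity of the group on the ring and its place there, so the compounds shown cannot separate the two; 3-bromophenyl or 4-methoxyphenyl on the same amine nitrogen would be the direct comparisons. Going by these compounds, it also remains open how the core of compound 1 would respond to a group of a different kind at this nitrogen, such as a cyclohexyl ring or a phenyl ring carrying a carboxylic acid.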